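The source may report more compounds than this note shows. Statements on the series, on what has been measured and on what is new or still open speak of the compounds shown alone.

In a functional assay on NIH3T3 cells (Mus musculus) for inhibition (a higher number here means a weaker inhibitor, a lower number a stronger inhibitor), the measured compounds are:
Compound 1 `CCCCCCCCCCCCCCCC(=O)C[C@H](COP(=O)(O)O[C@H]1[C@@H](O)[C@@H](O)[C@H](O)C[C@H]1O)C(=O)CCCCCCCCCCCCCCC`: 14000 nM
Compound 2 `CCCCCCCCCCCCCCCCCCOC[C@H](COP(=O)(O)O[C@@H]1[C@H](O)[C@@H](CO)[C@@H](O)[C@H](O)[C@@H]1O)OC`: 2000 nM

Compound 2 has the lower number of the two and is therefore the stronger inhibitor, with a gap to compound 1 that lies beyond the scatter. Compound 3 `CCCCCCCCCCCCCCCCCCOC[C@H](COP(=O)(O)O[C@@H]1[C@H](O)[C@@H](CO)[C@@H](O)[C@H](O)[C@@H]1O)n1ccnc1` has not yet been measured. It carries 1H-imidazol-1-yl in place of methoxy on a saturated chain carbon bound to two saturated chain carbons. Among the measured compounds shown here, no measured pair shows a change in this place, so the expectation is loose: no step beyond the scatter in this assay. The expected change is a 1.3-fold higher number from compound 2 to compound 3 (0.10 log units; within the scatter). For compound 3 the estimated value is 2500 nM, with an expected range of 700 nM to 9000 nM.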

Compound 3, half-maximal inhibitory concentration: 8200 nM
The estimate for compound 3 lay 3.3-fold (0.52 log units) below the measured number; low and high end bracket the measured number.
By their numbers in this assay, from the lowest: compound 2; then compounds 3 and 1 (each within the scatter of the next).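

Among the compounds shown here, this is the first change seen at this saturated chain carbon bound to two saturated chain carbons. In this assay, 1H-imidazol-1-yl in place of methoxy gives a 4.1-fold higher number from compound 2 to compound 3 (0.61 log units; beyond the scatter), so the inhibition responds to what sits at this position, and here the change weakens it. Nothing measured here accounts for this step.

The compounds shown leave open how an amine, a hydroxyl or an ethoxy group would fare on this carbon. A single pair also cannot separate the effect of the aromatic ring from that of the added heavy atoms.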